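This account rests on a few compounds, and the source may have more. Where it says the series, first, only, none or still open, it means among the compounds named here.

In an ADME assay on microsomes from liver (Homo sapiens) for metabolic stability, read by LC-MS, with a stated time of 40 min (on this read-out lower numbers stand for slow clearance and higher numbers for fast clearance), compound 1 (`Cc1ccc(C(=O)N(CC(=O)NCc2ccccc2)Cc2ccc(C(=O)NO)cc2)c(C)c1`) gives 86 mL.min-1.g-1 and compound 2 (`Cc1ccc(C(=O)N(CC(=O)NC2CCCCC2)Cc2ccc(C(=O)NO)cc2)c(C)c1`) gives 139 mL.min-1.g-1, so the two sit within the scatter of each other. Compound 3 (`O=C(CN(Cc1ccc(C(=O)NO)cc1)C(=O)c1cccc2ccccc12)NCc1ccccc1`) keeps the core of compound 1 and changes one group: naphthalen-1-yl in place of 2,4-dimethylphenyl on a carbonyl carbon. Within the data shown here, the only measured step, a 1.6-fold higher number from compound 1 to compound 2 (0.21 log units; within the scatter), lies on the amide-type nitrogen, not on the carbonyl carbon, so it bears only indirectly, and no measured step covers this change. No step beyond the scatter is therefore expected in this assay. The expected step is a 1.2-fold higher number from compound 1 to compound 3 (0.07 log units; within the scatter). For compound 3 the estimated value is 100 mL.min-1.g-1, with an expected range of 45 mL.min-1.g-1 to 220 mL.min-1.g-1.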

Compound 3, intrinsic clearance in microsomes: 41 mL.min-1.g-1
Compound 3: the middle estimate sits 2.4-fold (0.39 log units) above what was measured; measured number below the stated range.
By their numbers in this assay, from the lowest: compound 3; then compounds 1 and 2 (each within the scatter of the next).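

In this assay, among these compounds, the place on a carbonyl carbon carries the only step beyond the scatter so far: naphthalen-1-yl in place of 2,4-dimethylphenyl gives a 2.1-fold lower number from compound 1 to compound 3 (0.32 log units; beyond the scatter) and the size of the step is modest. The change on the amide-type nitrogen, a 1.6-fold higher number from compound 1 to compound 2 (0.21 log units; within the scatter), stays within the scatter. No evidence on the origin of the new step is available.

Going by these compounds, whether naphthalen-1-yl gives a lower number alongside cyclohexyl on the amide-type nitrogen remains open. So does the outcome with a morpholine or a longer alkyl chain on the carbonyl carbon.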